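Adding a 2-methylbenzyl arm to a rhodanine diene

The source may hold more compounds than are shown below. What is called first, only, known or untested is meant among the compounds shown, and "the series" means these compounds.

Measured compounds:
- compound 1, `O=C1NC(=S)S/C1=C\C=C\c1ccccc1`: 37.4%
- compound 2, `O=C1NC(=S)S/C1=C\C=C\c1ccccc1OCc1ccncc1`: 39.4%
- compound 3, `COc1ccccc1/C=C/C=C1\SC(=S)NC1=O`: 41.7%

Compound 3, `COc1ccccc1/C=C/C=C1\SC(=S)NC1=O`, gives 41.7% in an assay on isolated protein for inhibition of protein tyrosine phosphatase type IVA 3 (Homo sapiens), tested at 5 ug/mL (on this read-out higher numbers stand for more inhibition at the one concentration tested (going by the name of the read-out) and lower numbers for less inhibition), the highest of the three numbers, though its lead over compound 2 (a number 2.3 percentage points higher from compound 2 to compound 3 (within the scatter)) and over compound 1 (a number 4.3 percentage points higher from compound 1 to compound 3 (within the scatter)) stays within the scatter, so the three compounds cannot be ranked.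

Compound 4, `Cc1ccccc1COc1ccccc1/C=C/C=C1\SC(=S)NC1=O`, is not yet measured. It differs from compound 3 in one place: 2-methylphenyl in place of hydrogen on a saturated chain carbon bound to an oxygen on an aromatic ring.

Going by the values given here, the step that bears most on this change is the one from compound 2 to compound 3, where a pyridin-4-yl on that same chain carbon was exchanged for hydrogen: a number 2.3 percentage points higher from compound 2 to compound 3 (within the scatter). A ring hanging from this carbon, in that case, made no difference beyond the scatter. The steps from compound 1 to compound 2 (a number 2 percentage points higher from compound 1 to compound 2 (within the scatter)) and to compound 3 (a number 4.3 percentage points higher from compound 1 to compound 3 (within the scatter)) were likewise small.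

The change from compound 3 to compound 4 is therefore expected to be a number 1.7 percentage points lower from compound 3 to compound 4 (within the scatter), not beyond the scatter. Compound 4 is estimated at 40%, within 28% to 52%.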

Compound 4, a percentage reported as inhibition, at one concentration (the size of the read-out at that concentration, not a potency): 52.8%
Compound 4: middle estimate off by 12.8 percentage points, on the low side, and the stated range ends below it.
By their numbers in this assay, from the lowest: compounds 1, 2 and 3 (each within the scatter of the next); then compound 4.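

The chain carbon bound to an oxygen on an aromatic ring can clearly affect the result in this assay: placing 2-methylphenyl there in place of hydrogen gives a number 11.1 percentage points higher from compound 3 to compound 4 (beyond the scatter), a step beyond the scatter. Simply having a ring on this carbon does not settle the outcome, since pyridin-4-yl and hydrogen there stayed within the scatter of each other, while 2-methylphenyl in place of pyridin-4-yl gives a number 13.4 percentage points higher from compound 2 to compound 4 (beyond the scatter) and so shows that the kind of ring counts. Nothing available here explains why these two rings differ.

The compounds shown leave open how much of the gain belongs to the methyl, as a plain phenyl on this carbon would be needed to separate it from the ring. They also leave open what a ring carrying an amine or a carboxylic acid would give at this place.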